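The compounds below may be only part of what the source reports. "The series", "measured", "known", "first", "only" and "open" are said of these compounds alone.

Measured compounds in a toxicity assay on the whole organism with Mus musculus as the target, in the rotarod test; a lower number here means that less compound is needed, a higher number that more compound is needed for the effect:
compound 1, `Cc1ccc2c(c1)C(c1ccc(N)cc1)NC(=O)C2(C)C`: 1030 mg/kg
compound 2, `CC1(C)C(=O)NC(c2ccccc2N)c2ccccc21`: a limit, > 1000 mg/kg
compound 3, `CCNCC(=O)Nc1ccc(C2NC(=O)C(C)(C)c3ccccc32)cc1`: 760 mg/kg

Compound 3 holds the lowest of the two numbers in this assay; the nearest is compound 1 at 1030 mg/kg, a gap within the scatter, so no order between the two is claimed. For compound 2 this assay reports only a limit, > 1000 mg/kg, and no number. Compound 4, `CCN(CC)CC(=O)Nc1ccc(C2NC(=O)C(C)(C)c3ccccc32)cc1`, is not yet measured in this assay. It differs from compound 3 in one place: ethyl in place of hydrogen on an amine nitrogen. Among the measured compounds shown here, no measured pair carries this change. The expectation is a small step, a 1.1-fold higher number from compound 3 to compound 4 (0.05 log units; within the scatter), not beyond the scatter in either direction. Compound 4 is accordingly estimated at 850 mg/kg, with a range from 500 mg/kg to 1400 mg/kg.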

Compound 4, dose for half-maximal effect: 1300 mg/kg
Compound 4: middle estimate off by 1.5-fold (0.18 log units), on the low side; the measured number falls inside the stated range.
By their numbers in this assay, from the lowest: compounds 3, 1 and 4 (each within the scatter of the next).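

Among the compounds shown here, this is the first measured pair at this amine nitrogen: in this assay the change from ethylamino to diethylamino gives a 1.7-fold higher number from compound 3 to compound 4 (0.23 log units; within the scatter) and so does not separate the two compounds. Ethyl in place of hydrogen at this position therefore leaves the number within the usual scatter, though one pair sets no pattern. Nothing at hand bears on a cause for this step.

Going by these compounds, whether a longer chain such as dipropylamino, or a ring amine such as piperidine or morpholine, would step beyond the scatter remains open. So does the effect of a carboxylic acid at this position.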